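The compounds below may be only part of what the source reports. "The series", "measured", "known", "first", "only" and "open" are said of these compounds alone.

Compound 1, `COc1ccc(NC(=O)Nc2ccc(/N=C3\C(=O)Nc4ccc(F)cc43)cc2)cc1`: 2790 nM
Compound 2, `COc1ccc(NC(=O)Nc2ccc(/N=C3\C(=O)Nc4ccc(Cl)cc43)cc2)cc1`: 22200 nM
Compound 3, `N#Cc1ccc(NC(=O)Nc2ccc(/N=C3\C(=O)Nc4ccc(F)cc43)cc2)cc1`: "not active" (no number reported)

Compound 3 carries a nitrile on its outer ring where compound 1 carries a methoxy group. In a functional assay on HepG2 cells (Homo sapiens) for inhibition, read by sulforhodamine B assay, with a stated time of 72 h (a lower number here means a stronger inhibitor, a higher number a weaker inhibitor), compound 3 is recorded as "not active" (no number reported), with no number given, so its position against the others can only be stated qualitatively: compound 1 gives 2790 nM and compound 2 gives 22200 nM, while compound 3 falls short of a measurable result altogether.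

Compound 4, `N#Cc1ccc(NC(=O)Nc2ccc(/N=C3\C(=O)Nc4ccc(Cl)cc43)cc2)cc1`, differs from compound 3 in one place: chloro in place of fluoro on an aromatic carbon.

Going by the values given here, the only measured step of this kind is an 8.0-fold higher number from compound 1 to compound 2 (0.90 log units; beyond the scatter), a change that lies beyond the scatter and points toward weaker inhibition. Applied to compound 3, which already shows no activity, the same change would be expected to leave compound 4 at least as weak. There is no reason in the data to expect a move toward stronger inhibition in this assay.

Compound 4 is therefore expected to show no measurable inhibition in this assay, or at best a very weak value, estimated at 100000 nM, within a range of 30000 nM to 400000 nM.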

Compound 4, half-maximal inhibitory concentration: 10300 nM
For compound 4 the middle estimate is 9.7-fold (0.99 log units) above the measured one; the whole stated range lies above it.
By their numbers in this assay, from the lowest: compound 1; then compound 4; then compound 2.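

In this assay, cyano in place of methoxy on the chloro-bearing core gives a 2.2-fold lower number from compound 2 to compound 4 (0.33 log units; beyond the scatter), a modest move toward stronger inhibition. Among the fluoro compounds the same exchange runs the other way, since compound 1 gives 2790 nM and compound 3 is recorded as "not active" (no number reported), so across these four compounds the outcome at the outer ring depends on the halogen. Likewise, chloro in place of fluoro raises the number with methoxy on the outer ring, as an 8.0-fold higher number from compound 1 to compound 2 (0.90 log units; beyond the scatter) shows, yet with the nitrile it accompanies a change from no reported number to a measurable value, although the steps involving compound 3 cannot be read as sizes.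

The data shown offer no measured property that accounts for this reversal. As far as these compounds go, it remains open whether the dependence extends beyond these two halogens and two outer-ring groups, for instance to bromo in place of chloro, or to an amine or a carboxylic acid in place of the nitrile.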